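A few compounds are considered here, and "the series" means these few. Any claim that something is new, unique, unknown or untested is made for them only; others in the source may bear on it.

Compound 1 `CN(C)C(=O)c1cc2cnc(Nc3ccc(NC(=O)C4(C(=O)Nc5ccc(F)cc5)CC4)cc3F)nc2n1C1CCCC1` gives 6.6% in a functional assay on SiHa cells (Homo sapiens) for inhibition, read by CCK-8 assay, with a stated time of 72 h, tested at 1 uM; a higher number here means more inhibition of growth at the concentration tested, a lower number less inhibition of growth.
Compound 2 `CN(C)C(=O)c1cc2cnc(Nc3ccc(NC(=O)C4(C(=O)Nc5cccc(Cl)c5)CC4)cc3)nc2n1C1CCCC1` gives 16.2% in this assay.
Compound 3 `CN(C)C(=O)c1cc2cnc(Nc3ccc(N)cn3)nc2n1C1CCCC1` gives -21.2% in this assay.

Among these three, compound 2 has the highest number in this assay. Its nearest neighbour is compound 1, whose value of 6.6% lies within the scatter of compound 2, so the two cannot be told apart on this evidence. Compound 3, with -21.2%, stands beyond the scatter below compound 2.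

The step under consideration leads from compound 2 to compound 4 `CN(C)C(=O)c1cc2cnc(Nc3ccc(NC(=O)C4(C(=O)Nc5ccc(Cl)cc5)CC4)cc3)nc2n1C1CCCC1`. The two share every atom, and the change is confined to one group: 4-chlorophenyl in place of 3-chlorophenyl on an amide-type nitrogen. Among the compounds with values here, nothing among the measured compounds isolates this change on its own, so no measured step can guide the size of the effect. Given that compound 1 and compound 2 differ in more than this and still lie within the scatter of each other, the step from compound 2 to compound 4 is expected to be small, with no clear direction, and the estimated step is a number 3.2 percentage points lower from compound 2 to compound 4 (within the scatter). Compound 4 is therefore expected to give about 13% in this assay, estimated between 0% and 26%.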

Compound 4, percent growth inhibition at one concentration: -0.8%
Compound 4: the middle estimate sits 13.8 percentage points above what was measured, and the stated range ends above it.
By their numbers in this assay, from the lowest: compound 3; then compounds 4, 1 and 2 (each within the scatter of the next, the first and the last beyond it).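

In this assay, within the data shown here, the exchange of 3-chlorophenyl for 4-chlorophenyl on an amide-type nitrogen is a number 17 percentage points lower from compound 2 to compound 4 (beyond the scatter), the first measured change confined to this one group. The two groups have the same heavy atoms and the same counts of hydrogen-bond donors and acceptors, so this pair shows that the place of the chlorine alone can separate two values at the single concentration tested. Nothing shown here explains that separation.

Compound 1 carries a 4-fluorophenyl group but differs from compound 4 in more than one place, so it cannot show how the halogen itself contributes. The compounds shown also leave open how a phenyl ring bearing a methoxy group or a carboxylic acid in place of the chlorine would behave at this position.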